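A few compounds are considered here, and "the series" means these few. Any claim that something is new, unique, unknown or untested is made for them only; others in the source may bear on it.

Among the compounds with values here, compound 3 `Cc1cc(-c2nc(C(c3ccc(F)cc3)c3ccc(F)cc3)sc2CC(=O)O)cnc1N` stands at the top of the three numbers so far: in an in vitro functional assay on HEK285-7 cells for antagonist activity at prostaglandin D2 receptor 2 (Homo sapiens), read by BRET and beta-arrestin recruitment (a higher number here means a larger maximal response, a lower number a smaller maximal response), compound 3 gives 80%, level with compound 2 `O=C(O)Cc1sc(C(c2ccc(F)cc2)c2ccc(F)cc2)nc1-c1ccoc1`, which in this assay gives 80%, and well clear of compound 1 `Nc1cc(-c2nc(C(c3ccc(F)cc3)c3ccc(F)cc3)sc2CC(=O)O)cc(F)n1`, which in this assay gives 30%. The three differ only in the aromatic group on one carbon of the shared core.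

Compound 4 `O=C(O)Cc1sc(C(c2ccc(F)cc2)c2ccc(F)cc2)nc1-c1ccncc1` is the next member and is not yet measured. Relative to compound 3 the change is pyridin-4-yl in place of 6-amino-5-methylpyridin-3-yl on an aromatic carbon.

Within the data shown here, three measured steps bear on this position. no change at the digits printed from compound 2 to compound 3 (within the scatter) shows that an exchange of aromatic groups at this carbon can leave the maximal response unmoved. a number 50 percentage points higher from compound 1 to compound 2 (beyond the scatter) and a number 50 percentage points higher from compound 1 to compound 3 (beyond the scatter), on the other hand, show that the same position can shift the response by a large amount, with compound 1 well below the other two. The pyridin-4-yl of compound 4 is none of the three groups already tested, so the direction is not settled by the data and the outcome could fall at either level seen. For compound 4 in this assay the estimate is therefore placed between the two observed levels, at 60% with a range of 30% to 85%. Against compound 3 the expected change is a number 20 percentage points lower from compound 3 to compound 4 (beyond the scatter), a drop, with the range wide enough to take in no change at all.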

Compound 4, largest response reached (reported as efficacy), in percent of the reference or control that the assay uses: 80%
Compound 4: middle estimate off by 20 percentage points, on the low side; low and high end bracket the measured number.
By their numbers in this assay, from the lowest: compound 1; then compounds 2, 3 and 4 (each within the scatter of the next).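

In this assay, pyridin-4-yl gives no change at the digits printed from compound 3 to compound 4 (within the scatter) and no change at the digits printed from compound 2 to compound 4 (within the scatter), so the amino and methyl groups of the 6-amino-5-methylpyridin-3-yl are not needed to hold this level of maximal response. With a number 50 percentage points higher from compound 1 to compound 4 (beyond the scatter), the position now reads as three compounds at one level and one apart: furan-3-yl, 6-amino-5-methylpyridin-3-yl and pyridin-4-yl sit together, and only the 2-amino-6-fluoropyridin-4-yl of compound 1 stands lower, with pyridin-4-yl differing from it only in lacking the amino group and the fluorine. No measurement at hand accounts for the lower response of compound 1.

The compounds shown do not separate the amino group from the fluorine in that step, and a 2-aminopyridin-4-yl or a 2-fluoropyridin-4-yl group on this carbon would tell the two apart. Also open, as far as these compounds go, is how a saturated ring with an amine, such as piperidin-4-yl, would compare on this carbon with the aromatic groups seen so far.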